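Para substituents on the phenyl ring: methyl after chloro

The compounds below may be only part of what the source reports. "The series", "measured", "known", "first", "only" and "open" are said of these compounds alone.

Compound 1 `CN(C)C/C=C(/c1ccccc1)c1cccnc1`: 107 umol/kg
Compound 2 `CN(C)C/C=C(/c1ccc(Cl)cc1)c1cccnc1`: 38 umol/kg
Compound 3 `CN(C)C/C=C(/c1ccc(C(F)(F)F)cc1)c1cccnc1`: > 101 umol/kg

In an in vivo functional assay on the whole organism (brain) for inhibition of Norepinephrine transporter (Rattus norvegicus) (a higher number here means that more compound is needed for the effect, a lower number that less compound is needed), compound 1 gives 107 umol/kg, the highest of the two numbers seen. Compound 2 gives 38 umol/kg, so a 2.8-fold lower number from compound 1 to compound 2 (0.45 log units; beyond the scatter). Compound 3 gives > 101 umol/kg, which is a limit of the assay and not a number. Thus a step that the limit leaves unreadable from compound 1 to compound 3 owing to the limit of > 101 umol/kg in this assay, at which 1 of the 3 values shown sits, and an at least 2.6-fold higher number from compound 2 to compound 3 (0.42 log units; beyond the scatter).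

Compound 4 `Cc1ccc(/C(=C/CN(C)C)c2cccnc2)cc1` differs from compound 1 by methyl in place of hydrogen on an aromatic carbon. The chloro step lowered the number modestly, while the trifluoromethyl step could not be read, so for methyl the expectation in this assay is a 1.5-fold lower number from compound 1 to compound 4 (0.18 log units; within the scatter), a change not beyond the scatter. Compound 4 is therefore estimated at 70 umol/kg, between 30 umol/kg and 160 umol/kg.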

Compound 4, dose for half-maximal effect: > 117 umol/kg
Compound 4 ended at the assay's limit; the forecaster's own chance of this, stated with the estimate: 20%; at least 1.6-fold (0.22 log units) between middle value and limit.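

Compound 4 stands at a limit of the assay, not at a number: the limit of > 117 umol/kg in this assay, at which 1 of the 4 values shown sits. In this assay, methyl in place of chloro gives an at least 3.0-fold higher number from compound 2 to compound 4 (0.48 log units; beyond the scatter), and methyl in place of hydrogen gives an at least 1.0-fold higher number from compound 1 to compound 4 (0.03 log units; that floor lies within the scatter), so at this position the lowering seen with chloro does not carry over to methyl. The step between compound 3 and compound 4 cannot be read.

On these data alone, how far compound 4 lies past its limit stays open. So does whether chloro stands alone at this position, which bromo or fluoro could test.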